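This account rests on a few compounds, and the source may have more. Where it says the series, first, only, none or still open, it means among the compounds named here.

Compound 1 `NC1=NC2(CCSCC2)N(OCCCOc2ccc(Br)cc2)C(N)=N1` gives 740 nM in a functional assay on A549 cells (Homo sapiens) for antiproliferative activity, read by MTT assay, with a stated time of 72 h; a lower number here means a stronger inhibitor, a higher number a weaker inhibitor.
Compound 2 `NC1=NC2(CCOCC2)N(OCCCOc2cccc(Cl)c2Cl)C(N)=N1` gives 100 nM.
Compound 3 `NC1=NC2(CCSCC2)N(OCCCOc2ccccc2Br)C(N)=N1` gives 40 nM.

All three share one core, with a sulfur in the core of compound 1 and compound 3 where compound 2 carries an oxygen, and they differ in the aryl group sitting on the oxygen on a saturated carbon. Among the three values, compound 2 stands second highest: its number lies closest to that of compound 3 and furthest from that of compound 1.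

Compound 4 `Cc1ccc(OCCCON2C(N)=NC(N)=NC23CCOCC3)cc1` has not yet been measured. It differs from compound 2 in one place: 4-methylphenyl in place of 2,3-dichlorophenyl on an oxygen on a saturated carbon.

Going by the values given here, only one measured step changes this aryl group, a 19-fold lower number from compound 1 to compound 3 (1.27 log units; beyond the scatter), and it moves a single bromine around the ring rather than swapping halogens for a methyl group. It is therefore an indirect guide at best. What can be said is that compound 1, whose 4-bromophenyl group carries its substituent in the same position as the 4-methylphenyl of compound 4, has the highest number of the three, and that compound 4 gives up both chlorines. On that thin basis a step towards a higher number is expected, a 5.0-fold higher number from compound 2 to compound 4 (0.70 log units; beyond the scatter), though with wide uncertainty. Compound 4 is estimated at 500 nM, within a range from 150 nM to 2000 nM.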

Compound 4, half-maximal inhibitory concentration: 1060 nM
The estimate for compound 4 lay 2.1-fold (0.33 log units) below the measured number; low and high end bracket the measured number.
By their numbers in this assay, from the lowest: compound 3; then compound 2; then compounds 1 and 4 (each within the scatter of the next).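

In this assay, going by these compounds alone, replacing 2,3-dichlorophenyl with 4-methylphenyl gives an 11-fold higher number from compound 2 to compound 4 (1.03 log units; beyond the scatter) and shows that the aryl group on this oxygen matters on the core with the ring oxygen, whereas the only earlier step at this position, a 19-fold lower number from compound 1 to compound 3 (1.27 log units; beyond the scatter), was on the sulfur-containing core. The earlier step moved a single bromine around the ring, but this one changes the substituents themselves, with two chlorines leaving and one methyl entering, and the ring stays a six-membered aromatic ring of carbon only, so a change confined to the groups on that ring is enough for a large shift in the number. Nothing available here explains why this swap has so large an effect.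

The compounds shown leave open how much of the step comes from losing the chlorines and how much from gaining the methyl, a question that a phenyl group with no substituent on the same core could help to separate. They also leave open how the number would respond to a longer chain between the core and the aryl group, or to an amine on the ring.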